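The compounds below may be only part of what the source reports. "The series", "measured", "known", "first", "only" and "open" are said of these compounds alone.

Among the measured compounds shown here, compound 1 `[O-][n+]1nc(NCOC2CCCCC2)[n+]([O-])c2ccccc21` was tested in a functional assay on SMMC-7721 cells (Homo sapiens) for cytotoxicity, read by MTT assay, with a stated time of 72 h (a higher number here means a weaker inhibitor, a lower number a stronger inhibitor), and gave 28200 nM, the highest of the two numbers known. Compound 2 `COc1ccc2c(c1)[n+]([O-])nc(NCOCc1ccccc1)[n+]2[O-]` in this assay gave 21400 nM, which lies within the scatter of that of compound 1, so no order between the two can be read. Compound 3 `CCCCOCNc1n[n+]([O-])c2ccccc2[n+]1[O-]` differs from compound 1 by one change: butyl in place of cyclohexyl on an oxygen on a saturated carbon. For the measured compounds named here, no measured pair shows the effect of such a swap, so the step is expected to be small, at most a slight weakening, at a 1.2-fold higher number from compound 1 to compound 3 (0.09 log units; within the scatter). Compound 3 is therefore estimated at 35000 nM, with a range of 12000 nM to 95000 nM.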

Compound 3, half-maximal inhibitory concentration: 21100 nM
The estimate for compound 3 lay 1.7-fold (0.22 log units) above the measured number, and the stated range covers the measured number.
By their numbers in this assay, from the lowest: compounds 3, 2 and 1 (each within the scatter of the next).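

On an oxygen on a saturated carbon, butyl in place of cyclohexyl gives a 1.3-fold lower number from compound 1 to compound 3 (0.13 log units; within the scatter) in this assay. Among the compounds shown here, this is the first measured step at this position, and it shows that an open chain can take the place of the ring with no change that can be read beyond the scatter. No available evidence bears on this result.

Open, on these data alone, is how this position responds to a much shorter chain such as methyl, a longer chain such as octyl, or a chain that ends in an amine.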